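Acetoxy gives way to isobutoxy

The compounds below may be only part of what the source reports. "The series", "measured", "known", "first", "only" and "open" are said of these compounds alone.

In a functional assay on A549 cells (Homo sapiens) for cytotoxicity, with a stated time of 48 h (on this read-out higher numbers stand for weaker inhibition and lower numbers for stronger inhibition), compound 1 (`Cc1ccc2c(=O)cc(/C=C/[S+](C)[O-])oc2c1`) gives 2000 nM and compound 2 (`CC(=O)Oc1ccc2oc(/C=C/[S+](C)[O-])cc(=O)c2c1`) gives 4100 nM as the higher of the two numbers, a gap beyond the usual scatter. Compound 3 (`CC(C)COc1ccc2oc(/C=C/[S+](C)[O-])cc(=O)c2c1`) has not yet been measured. It carries isobutyl in place of acetyl on an oxygen on an aromatic ring. Within the data shown here, no measured pair shows this change, so only a small move toward stronger inhibition is expected, with nothing beyond the scatter. In this assay the expected step is a 1.4-fold lower number from compound 2 to compound 3 (0.14 log units; within the scatter) by this estimate. For compound 3 the estimate is 3000 nM with a range from 1000 nM to 9000 nM expected.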

Compound 3, half-maximal inhibitory concentration: 1100 nM
The estimate for compound 3 lay 2.7-fold (0.44 log units) above the measured number; measured number inside the range.
By their numbers in this assay, from the lowest: compounds 3 and 1 (each within the scatter of the next); then compound 2.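

Among these compounds, exchanging acetoxy for isobutoxy gives a 3.7-fold lower number from compound 2 to compound 3 (0.57 log units; beyond the scatter) in this assay, the first reading of a change made at this position alone. It shows that the number responds to what sits on this oxygen on an aromatic ring. The change removes the acetyl double bond and hydrogen-bond acceptor, but no available evidence explains the step.

Going by these compounds, how a free hydroxyl, a methoxy or a longer chain on this oxygen would read remains open. So does whether an ester larger than acetyl would follow acetoxy or isobutoxy.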